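The source may report more compounds than this note shows. Statements on the series, on what has been measured and on what is new or still open speak of the compounds shown alone.

Within the data shown here, in a functional assay on HL-60 cells (Homo sapiens) for antiproliferative activity, read by MTT assay (a lower number here means a stronger inhibitor, a higher number a weaker inhibitor), compound 2 (`C=CC[C@@H]1O[C@H](COCc2ccccc2)[C@@H](OCc2ccccc2)[C@H](OCc2ccccc2)[C@H]1O`) gives 15100 nM and holds the only number so far. Compound 1 (`O[C@@H]1[C@@H](OCc2ccccc2)[C@H](OCc2ccccc2)[C@@H](COCc2ccccc2)O[C@@H]1c1ccccc1`), also bearing phenyl, is reported as "not active" (no number reported) with no number. Compound 3 (`O[C@@H]1[C@@H](OCc2ccccc2)[C@H](OCc2ccccc2)[C@@H](COCc2ccccc2)O[C@H]1c1ccccc1`) carries phenyl in place of allyl on a saturated ring carbon. Among the measured compounds shown here, no measured step shows the size of this change in this assay so the direction rests on compound 1 alone, whose result of "not active" (no number reported) points towards a weaker inhibitor. The expected change is modest and may not exceed the scatter (a 2.0-fold higher number from compound 2 to compound 3 (0.30 log units; within the scatter)). For compound 3 the estimate is 30000 nM (expected range 10000 nM to 90000 nM).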

Compound 3, half-maximal inhibitory concentration: 26300 nM
For compound 3 the middle estimate is 1.1-fold (0.06 log units) above the measured one; the range from low to high includes it.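

With one configuration, phenyl on this saturated ring carbon gives a measurable result in this assay that is not separated from allyl: a 1.7-fold higher number from compound 2 to compound 3 (0.24 log units; within the scatter). The phenyl result also proves sensitive to configuration, since compound 1 gives "not active" (no number reported) while compound 3 gives 26300 nM, a contrast that can be traced to one structural difference: the fact that compounds 1 and 3 differ only in the configuration as drawn

Still open, from the compounds shown here alone, is how an amine or a longer saturated chain would read on this carbon. Also open, going by these compounds, is whether allyl shows the same dependence on configuration as phenyl.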